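The source may report more compounds than this note shows. Statements on the series, on what has been measured and on what is new or still open speak of the compounds shown alone.

Measured compounds:
Compound 1, `Clc1ccc(C(C2Cc3ccccc3O2)n2cncn2)c(Cl)c1`: in an assay for inhibition of Aromatase (Homo sapiens) (a higher number here means a weaker inhibitor, a lower number a stronger inhibitor), compound 1 gives 880 nM.
Compound 2, `Clc1ccc(C(C2Cc3ccccc3O2)n2cnnn2)cc1`: in this assay compound 2 gives 3000 nM.

Of the two numbers in this assay, compound 2 has the higher one; its nearest neighbour is compound 1, whose number is lower by a margin that lies beyond the scatter. Compound 1 and compound 2 differ from each other in two places at once, so their two values show only that much and no single step can be read from them.

The step now followed leads from compound 2 to compound 3, `Clc1ccc(C(C2Cc3ccccc3O2)n2cnnn2)c(Cl)c1`. The change is chloro in place of hydrogen on an aromatic carbon, and nothing else about the structure moves. Among the compounds with values here, no step between measured compounds is available for this kind of change, so the expectation rests on the values at hand alone. Compound 1 carries the same pair of chloro groups that compound 3 would carry, and it gives the lower of the two numbers; on that basis a moderate fall in this assay, beyond the scatter but not large, is expected for compound 3, as a 2.1-fold lower number from compound 2 to compound 3 (0.33 log units; beyond the scatter).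

Compound 3 is therefore estimated at 1400 nM, with a range from 500 nM to 4000 nM.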

Compound 3, half-maximal inhibitory concentration: 52000 nM
Compound 3: middle estimate off by 37-fold (1.57 log units), on the low side; the measured number lies above the stated range.
By their numbers in this assay, from the lowest: compound 1; then compound 2; then compound 3.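

In this assay, within the data shown here, chloro in place of hydrogen on an aromatic carbon, ortho to a large group and meta to a chloro group, gives the first single change that can be read, and it brings a large loss of inhibition, with a 17-fold higher number from compound 2 to compound 3 (1.24 log units; beyond the scatter). With both chloro groups held in place, 1H-tetrazol-1-yl in place of 1H-1,2,4-triazol-1-yl also gives a large loss, with a 59-fold higher number from compound 1 to compound 3 (1.77 log units; beyond the scatter), so each single change leading to compound 3 moves the number sharply upward and compound 3 is the weakest inhibitor of the three. Nothing at hand accounts for the size of either step.

The compounds shown leave open whether the added chloro group would bring a similar loss with 1H-1,2,4-triazol-1-yl in place of 1H-tetrazol-1-yl, since its effect is seen with the tetrazole alone. They also leave open how a smaller fluoro group, a methyl group or a methoxy group would behave on that same aromatic carbon, and whether any of these would keep the number nearer that of compound 2.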